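Triazole Ester Series Where Every Value Is a Limit

The compounds below may be only part of what the source reports. "The series", "measured", "known", "first", "only" and "open" are said of these compounds alone.

Compound 1, `C/C(=C\CC/C(C)=C/CC[C@@H]1[C@@]2(C)CCC(=O)C(C)(C)[C@H]2CC[C@@]1(C)O)CC/C=C(\C)C(=O)OCc1cn(-c2ccc(C(F)(F)F)cc2)nn1`: > 150000 nM
Compound 2, `C/C(=C\CC/C(C)=C/CC[C@@H]1[C@@]2(C)CCC(=O)C(C)(C)[C@H]2CC[C@@]1(C)O)CC/C=C(\C)C(=O)OCc1cn(-c2ccccc2Br)nn1`: > 150000 nM
Compound 3, `C/C(=C\CC/C(C)=C/CC[C@@H]1[C@@]2(C)CCC(=O)C(C)(C)[C@H]2CC[C@@]1(C)O)CC/C=C(\C)C(=O)OCc1cn(-c2cccc(C)c2)nn1`: > 150000 nM

In a functional assay on A549 cells (Homo sapiens) for antiproliferative activity, read by MTT assay, with a stated time of 48 h (on this read-out higher numbers stand for weaker inhibition and lower numbers for stronger inhibition), none of the three compounds has given a measured number; each is reported only as a limit. Compound 1 reaches only the limit > 150000 nM. Compound 2 likewise gives only the limit > 150000 nM. Compound 3 also stops at the limit > 150000 nM. Compound 2 thus stands with no number of its own, at the point where the limit of > 150000 nM in this assay, at which 3 of the 3 values shown sit, sits. The steps a step that the two limits leave unreadable from compound 1 to compound 2, a step that the two limits leave unreadable from compound 1 to compound 3 and a step that the two limits leave unreadable from compound 2 to compound 3 are unreadable, since both ends of each are limits.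

Compound 4, `C/C(=C\CC/C(C)=C/CC[C@@H]1[C@@]2(C)CCC(=O)C(C)(C)[C@H]2CC[C@@]1(C)O)CC/C=C(\C)C(=O)OCc1cn(-c2cccc(F)c2)nn1`, differs from compound 2 in one place: 3-fluorophenyl in place of 2-bromophenyl on an aromatic nitrogen. The changes measured so far are all exchanges of the group on the aromatic nitrogen, and none of them produced a readable step in this assay, so the expected step is a step that the limit leaves unreadable from compound 2 to compound 4, nothing beyond the scatter. Compound 4 is estimated at 200000 nM, in a range from 100000 nM to 600000 nM, most likely again reported as a limit.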

Compound 4, half-maximal inhibitory concentration: 124000 nM
Compound 4: middle estimate off by 1.6-fold (0.21 log units), on the high side; the measured number falls inside the stated range.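

Among the compounds shown here, compound 4, with 3-fluorophenyl on the aromatic nitrogen, gives 124000 nM in this assay and is the first compound with a measured number rather than a limit. The change reads as an at least 1.2-fold lower number from compound 2 to compound 4 (0.08 log units; that floor lies within the scatter) and an at least 1.2-fold lower number from compound 3 to compound 4 (0.08 log units; that floor lies within the scatter) and an at least 1.2-fold lower number from compound 1 to compound 4 (0.08 log units; that floor lies within the scatter) but each of these is only a floor, and each floor stays within the scatter. This position can therefore carry a group that yields a readable number, yet that number does not place compound 4 in any firm order against the other three, which all sit at one limit: the limit of > 150000 nM in this assay, at which 3 of the 4 values shown sit.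

The compounds shown leave open how far the number would move with an amine or a carboxylic acid on that phenyl ring. They also leave open what a longer chain in place of the phenyl ring would do.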